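Replacing a thiophen-2-yl tail with ethoxycarbonyl

This account rests on a few compounds, and the source may have more. Where it says the series, first, only, none or still open, it means among the compounds named here.

Compound 1 `COc1cc(/C=C/C(=O)c2cccc(NC(=O)c3cccs3)c2)ccc1O`: 6.57 ug/mL
Compound 2 `COc1cc(/C=C/C(=O)c2cccc(NC(=O)c3ccco3)c2)ccc1O`: 0.76 ug/mL
Compound 3 `CCCC(=O)Nc1cccc(C(=O)/C=C/c2ccc(O)c(OC)c2)c1`: 3.94 ug/mL

The three measured compounds share one core and differ only in the group attached to the carbonyl carbon of the amide. In a functional assay on SiHa cells (Homo sapiens) for inhibition (on this read-out higher numbers stand for weaker inhibition and lower numbers for stronger inhibition), compound 1 stands at the highest of the three numbers. Its nearest neighbour is compound 3, and a 1.7-fold lower number from compound 1 to compound 3 (0.22 log units; within the scatter) lies within the scatter. Its furthest neighbour is compound 2, where an 8.6-fold lower number from compound 1 to compound 2 (0.94 log units; beyond the scatter) is a clear improvement.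

Compound 4 `CCOC(=O)C(=O)Nc1cccc(C(=O)/C=C/c2ccc(O)c(OC)c2)c1` has not yet been measured. Compared with compound 1, (ethoxycarbonyl in place of thiophen-2-yl on a carbonyl carbon). This group enters on a carbonyl carbon whose other neighbour is the amide-type nitrogen.

Within the data shown here, two measured steps bear on this change. Exchanging thiophen-2-yl for the acyclic propyl, a 1.7-fold lower number from compound 1 to compound 3 (0.22 log units; within the scatter), changed little. Exchanging it for furan-2-yl, an 8.6-fold lower number from compound 1 to compound 2 (0.94 log units; beyond the scatter), helped markedly, but ethoxycarbonyl carries no ring and so does not resemble that case. Among the measured compounds shown here, no measured step tests the ethoxycarbonyl group itself, so the expectation leans on the acyclic comparison and stays cautious.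

Compound 4 is therefore expected to show a 1.6-fold lower number from compound 1 to compound 4 (0.22 log units; within the scatter), a small shift towards a lower number in this assay, estimated at 4 ug/mL with a range from 1.3 ug/mL to 12 ug/mL.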

Compound 4, half-maximal inhibitory concentration: > 50 ug/mL
Compound 4: only a limit was reported; the forecaster's own chance of this, stated with the estimate: 5%; middle value at least 12-fold (1.09 log units) from the limit.
By their numbers in this assay, from the lowest: compound 2; then compounds 3 and 1 (each within the scatter of the next). At a limit, above all of these: compound 4.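

In this assay compound 4 carries a limit of the assay and not a number: the limit of > 50 ug/mL in this assay, at which 1 of the 4 values shown sits. Starting from compound 1, the earlier changes on this carbonyl carbon gave either a shift within the scatter or stronger inhibition, but ethoxycarbonyl in place of thiophen-2-yl weakens inhibition (an at least 7.6-fold higher number from compound 1 to compound 4 (0.88 log units; beyond the scatter)), and the gap to the furan-2-yl compound is wider still (an at least 65-fold higher number from compound 2 to compound 4 (1.81 log units; beyond the scatter)). Propyl has no ring either, yet ethoxycarbonyl in place of propyl also weakens inhibition (an at least 12-fold higher number from compound 3 to compound 4 (1.10 log units; beyond the scatter)), so among these compounds the lack of a ring does not by itself decide the outcome at this position.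

On these data alone, how far compound 4 lies beyond its limit stays open, so the true size of all three steps remains unknown. It is also unclear whether the loss follows the ester as a whole, its extra carbonyl or its ethyl end: a carboxylic acid, a methoxycarbonyl group or a longer alkyl chain on this carbonyl carbon could begin to separate these, and the compounds shown include none of them.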